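This account rests on a few compounds, and the source may have more. Where it says the series, first, only, none or still open, it means among the compounds named here.

Measured compounds: compound 1 `Clc1cncc(N2CCNCC2)c1`, compound 2 `Nc1cccc(-c2cncc(N3CCCNCC3)c2)c1`, compound 3 `c1cncc(-c2cncc(N3CCCNCC3)c2)c1`.

In an assay on cell membranes for binding affinity to Neuronal acetylcholine receptor; alpha4/beta2 (Rattus norvegicus), read by radioligand binding (on this read-out lower numbers stand for stronger inhibition and higher numbers for weaker inhibition), compound 1 gives 310 nM. Compound 2 gives 4 nM in this assay, and compound 3 gives 2.8 nM; the numbers of compound 2 and compound 3 lie within the scatter of each other, while compound 1 sits far apart from both. Compound 4 `NC(=O)c1cncc(N2CCCNCC2)c1` is not yet measured. It differs from compound 3 in one place: carbamoyl in place of pyridin-3-yl on an aromatic carbon. Within the data shown here, no step between measured compounds matches this change, so the expectation rests on the three numbers alone. For compound 4 a moderate step upward, beyond the scatter, is expected, an 11-fold higher number from compound 3 to compound 4 (1.03 log units; beyond the scatter). Compound 4 is estimated at 30 nM, with a range from 5 nM to 200 nM.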

Compound 4, half-maximal inhibitory concentration: 20 nM
For compound 4 the middle estimate is 1.5-fold (0.18 log units) above the measured one, and the stated range covers the measured number.
By their numbers in this assay, from the lowest: compounds 3 and 2 (each within the scatter of the next); then compound 4; then compound 1.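

In this assay, replacing pyridin-3-yl with carbamoyl at this position gives a modest loss, a 7.1-fold higher number from compound 3 to compound 4 (0.85 log units; beyond the scatter). Compound 2 and compound 3 both carry an aromatic ring here, whereas compound 4 shows that a smaller group with no ring still gives a measurable number in the same assay. No measured evidence explains this step. The compounds shown leave open whether the step follows from losing the ring or from the carbamoyl group itself. A nitrile, a carboxylic acid or a methyl-substituted amide at this place could help separate those two readings.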